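A few compounds are considered here, and "the series" means these few. Any claim that something is new, unique, unknown or untested is made for them only; others in the source may bear on it.

Compound 1 `NC[C@@H]1CCCc2cc(S(=O)(=O)c3cccc(F)c3)ccc21`: 0.0794 nM
Compound 2 `CN(C[C@@H]1CCCc2cc(S(=O)(=O)c3cccc(F)c3)ccc21)S(N)(=O)=O`: 3.98 nM
Compound 3 `CNC(=O)NC[C@@H]1CCCc2cc(S(=O)(=O)c3cccc(F)c3)ccc21`: 0.398 nM

These three compounds share one core and differ only in what is attached to the amine nitrogen of the chain. Measured in an assay on isolated protein for displacement of a labelled ligand from 5-hydroxytryptamine receptor 6 (Homo sapiens) (on this read-out higher numbers stand for weaker inhibition and lower numbers for stronger inhibition), compound 3 stands second among the three, with compound 1 at the lower number and compound 2 at the higher one. Compound 4 `CN(C)C(=O)NC[C@@H]1CCCc2cc(S(=O)(=O)c3cccc(F)c3)ccc21` carries the change (methyl in place of hydrogen on an amide-type nitrogen). Among the compounds with values here, three measured steps bear on it. Attaching methylcarbamoyl to the bare amine gave a 5.0-fold higher number from compound 1 to compound 3 (0.70 log units; beyond the scatter), so building on this nitrogen has cost something. The step of a 50-fold higher number from compound 1 to compound 2 (1.70 log units; beyond the scatter) is larger still, and the exchange a 10-fold lower number from compound 2 to compound 3 (1.00 log units; beyond the scatter) recovers part of that. None of these steps adds a methyl to an amide-type nitrogen, so the nearest guide is that every addition on this chain has so far raised the number. Compound 4 is therefore expected to show a small to modest rise in this assay, a 2.5-fold higher number from compound 3 to compound 4 (0.40 log units; beyond the scatter). The estimate for compound 4 is 1 nM, with a range from 0.3 nM to 4 nM.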

Compound 4, inhibition constant: 2.51 nM
Beside the measured number, compound 4's estimate is 2.5-fold (0.40 log units) below it; the range from low to high includes it.
By their numbers in this assay, from the lowest: compound 1; then compound 3; then compounds 4 and 2 (each within the scatter of the next).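

Replacing the amide hydrogen with a single methyl gives a 6.3-fold higher number from compound 3 to compound 4 (0.80 log units; beyond the scatter) in this assay, so one added carbon at this amide-type nitrogen is enough to change the result clearly. Built up from the bare amine, the dimethylcarbamoyl group gives a 32-fold higher number from compound 1 to compound 4 (1.50 log units; beyond the scatter), while (dimethylcarbamoyl)amino in place of methyl(sulfamoyl)amino gives a 1.6-fold lower number from compound 2 to compound 4 (0.20 log units; within the scatter), so these two groups cannot be told apart on this read-out. No measurement available here offers a reason for the methyl step.

On these data alone, it remains open whether a longer chain, such as ethyl, on this nitrogen would move the number further, or whether it is the methyl's presence alone that counts. Also open, as far as these compounds go, is how an acetyl group, which has no second nitrogen, would compare with compound 3.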